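A Methyl Added on the Core of Compound 1

The source may report more compounds than this note shows. Statements on the series, on what has been measured and on what is new or still open speak of the compounds shown alone.

For the measured compounds named here, compound 1 `CCOC(COC(N)=O)C1=C(N2CC2)C(=O)C(C)=C(N2CC2)C1=O` gives 4.62 in a functional assay on L1210 cells (Mus musculus), with a stated time of 1 days (on this read-out higher numbers stand for higher potency (the scale is a negative logarithm) and lower numbers for lower potency), the lower of the two numbers measured so far, while compound 2 `COCCOC(COC(N)=O)C1=C(N2CC2)C(=O)C(C)=C(N2CC2)C1=O` gives 4.96. Going by the values given here, the one measured step, a number 0.34 log units higher from compound 1 to compound 2 (beyond the scatter), concerns a different place in the molecule. Compound 3 `CCOC(COC(N)=O)C1=C(N2CC2)C(=O)C(CC)=C(N2CC2)C1=O` differs from compound 1 by methyl in place of hydrogen on a saturated chain carbon bound to a double-bonded ring carbon. Among the compounds with values here, no measured step touches this place, so the change is expected to stay within the scatter, with no change at the digits printed from compound 1 to compound 3 (within the scatter) as the estimated step. Compound 3 is therefore expected to give 4.62 in this assay, in the range from 4.2 to 5.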

Compound 3, logarithm of the reciprocal of the active concentration, log(1/C): 4.64
For compound 3 the middle estimate is 0.02 log units below the measured one; the measured number falls inside the stated range.
By their numbers in this assay, from the lowest: compounds 1 and 3 (each within the scatter of the next); then compound 2.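

In this assay, for the compounds shown here, methyl in place of hydrogen on a saturated chain carbon bound to a double-bonded ring carbon gives a number 0.02 log units higher from compound 1 to compound 3 (within the scatter) and so provides the first reading at this place. Methyl to ethyl here thus separates compound 3 from compound 1 by no more than the scatter, whereas the methoxy change elsewhere gives a number 0.34 log units higher from compound 1 to compound 2 (beyond the scatter) and lies beyond it. Nothing available explains this result. On these data alone, whether a longer chain, an amine or a carboxylic acid at this place would also stay within the scatter remains open.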